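This account rests on a few compounds, and the source may have more. Where it says the series, first, only, none or still open, it means among the compounds named here.

In a functional assay on HT-29 cells (Homo sapiens) for antiproliferative activity, read by MTT assay, with a stated time of 48 h (on this read-out lower numbers stand for stronger inhibition and higher numbers for weaker inhibition), the measured compounds are: compound 1, `O=C(/C=C\Nc1ccc(Cl)cc1)c1cn(-c2ccccc2)nc1-c1ccccc1`, 3610 nM; compound 2, `O=C(/C=C\Nc1ccc(Cl)cc1)c1cn(-c2ccccc2)nc1-c1ccc(F)cc1`, 4600 nM; compound 3, `O=C(/C=C\Nc1ccc(Cl)cc1)c1cn(-c2ccccc2)nc1-c1ccc(Cl)cc1`, 4650 nM.

Compound 3 gives the highest of the three numbers, but every step to it lies within the scatter: a 1.3-fold higher number from compound 1 to compound 3 (0.11 log units; within the scatter) and a 1.0-fold higher number from compound 2 to compound 3 (0.00 log units; within the scatter). Compound 4, `COc1ccc(N/C=C\C(=O)c2cn(-c3ccccc3)nc2-c2ccc(Cl)cc2)cc1`, differs from compound 3 by methoxy in place of chloro on an aromatic carbon. Among the measured compounds shown here, none of the measured steps touches that ring; the steps that exist, a 1.3-fold higher number from compound 1 to compound 2 (0.11 log units; within the scatter), a 1.3-fold higher number from compound 1 to compound 3 (0.11 log units; within the scatter) and a 1.0-fold higher number from compound 2 to compound 3 (0.00 log units; within the scatter), concern another aromatic ring and all stay within the scatter. On that basis no shift beyond the scatter is expected, and the estimated step is a 1.0-fold lower number from compound 3 to compound 4 (0.01 log units; within the scatter). Compound 4 is therefore expected to give 4500 nM, with a range from 1800 nM to 11000 nM.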

Compound 4, half-maximal inhibitory concentration: 8930 nM
The estimate for compound 4 lay 2.0-fold (0.30 log units) below the measured number; the range from low to high includes it.
By their numbers in this assay, from the lowest: compounds 1, 2, 3 and 4 (each within the scatter of the next, the first and the last beyond it).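

Exchanging the (4-chlorophenyl)amino group of compound 3 for (4-methoxyphenyl)amino is the first change shown on this ring, and in this assay it gives a 1.9-fold higher number from compound 3 to compound 4 (0.28 log units; within the scatter) and thus leaves chloro and methoxy at this position indistinguishable. No measured evidence bears on this result. As far as these compounds go, whether an amine or a carboxylic acid at this position would move the number beyond the scatter stays open. So does whether exchanging chloro for methoxy on the other 4-chlorophenyl ring would give a similar step.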